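A few compounds are considered here, and "the series" means these few. Any claim that something is new, unique, unknown or untested is made for them only; others in the source may bear on it.

Compound 2 `Cc1cccc(-c2sc(N)c(C(=O)c3ccc(Cl)cc3)c2CC(C)(C)C)c1` is a close relative of compound 1 `CC(C)(C)Cc1c(-c2cccnc2)sc(N)c1C(=O)c1ccc(Cl)cc1`. In an assay on CHO cells for displacement of a labelled ligand from adenosine receptor A1 (Homo sapiens), read by scintillation counting, tested at 10 uM (on this read-out higher numbers stand for more inhibition at the one concentration tested (going by the name of the read-out) and lower numbers for less inhibition), compound 1 gives 1%, and compound 2 gives 1%, so compound 2 stands level with compound 1 at these digits; the change no change at the digits printed from compound 1 to compound 2 (within the scatter) is within the scatter. Compound 3 `CC(C)c1ccc(-c2sc(N)c(C(=O)c3ccc(Cl)cc3)c2CC(C)(C)C)cc1` differs from compound 2 by 4-isopropylphenyl in place of 3-methylphenyl on an aromatic carbon. Going by the values given here, the only step that bears on this exchange of one aromatic ring for another is that from compound 1 to compound 2, which was flat, so no step beyond the scatter is expected, a number 2 percentage points higher from compound 2 to compound 3 (within the scatter). Compound 3 is therefore estimated at 3%, with a range from 0% to 15%.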

Compound 3, a percentage reported as inhibition, at one concentration (the size of the read-out at that concentration, not a potency): 1%
Compound 3: middle estimate off by 2 percentage points, on the high side; low and high end bracket the measured number.
By their numbers in this assay, from the lowest: compounds 1, 2 and 3 (each within the scatter of the next).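

With 4-isopropylphenyl in place of 3-methylphenyl there is no change at the digits printed from compound 2 to compound 3 (within the scatter) in this assay and with 4-isopropylphenyl in place of pyridin-3-yl there is no change at the digits printed from compound 1 to compound 3 (within the scatter) as well. The aromatic carbon next to the ring sulfur has now carried three different six-membered aromatic rings, and the reading stays the same even with the bigger 4-isopropylphenyl group of 9 heavy atoms.

From the compounds shown here alone, whether a ring bearing an amine or a carboxylic acid would move this reading remains open. No measurement at hand explains why the reading stays flat.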